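Trifluoromethyl for methoxy on an aryl ester

The source may hold more compounds than are shown below. What is called first, only, known or untested is meant among the compounds shown, and "the series" means these compounds.

Measured compounds:
compound 1 `COc1cccc(C(=O)Oc2cc3c(cc2C)[C@@H](C(C)C)CC=C3C)c1`: "not active" (no number reported)
compound 2 `CC1=CC[C@H](C(C)C)c2cc(C)c(OC(=O)c3cccc(C)c3)cc21`: "not active" (no number reported)
compound 3 `COc1ccc(C(=O)Oc2cc3c(C)ccc(C(C)C)c3cc2C)cc1`: 88.6%

Of the compounds shown here, three have been tested in a functional assay on K562 cells (Homo sapiens) for antiproliferative activity, read by sulforhodamine B assay, with a stated time of 48 h, tested at 50 uM; a higher number here means more inhibition at the concentration tested (going by the name of the read-out), a lower number less inhibition. Compound 1 and compound 2 were reported without a number. Compound 3 gives 88.6% in this assay, the only figure available, so it stands alone as the reference point for the series.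

Compound 4 `Cc1cc2c(C(C)C)ccc(C)c2cc1OC(=O)c1ccc(C(F)(F)F)cc1` has not yet been measured. It differs from compound 3 in one place: trifluoromethyl in place of methoxy on an aromatic carbon. Going by the values given here, no step between measured compounds exists to guide the size of this change. Because compound 3 already shows 88.6%, the expected step of a number 8.6 percentage points lower from compound 3 to compound 4 (within the scatter) in this assay is a modest decrease, possibly within the scatter. Compound 4 is thus estimated at 80%, with a range from 55% to 97%.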

Compound 4, a percentage reported as inhibition, at one concentration (the size of the read-out at that concentration, not a potency): 45.1%
Compound 4: the middle estimate sits 34.9 percentage points above what was measured; the whole stated range lies above it.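

Trifluoromethyl in place of methoxy, on an aromatic carbon para to a large group, gives in this assay a number 43.5 percentage points lower from compound 3 to compound 4 (beyond the scatter). Going by these compounds alone, this is the first measured step, and it shows that inhibition at the tested concentration depends on the group at this place. Nothing measured here offers an explanation for the size of this step. From the compounds shown here alone, what an amine or a carboxylic acid at this place would give remains open. Also open, going by these compounds, is whether the same change would have a similar effect on the core of compound 1.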